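Trading a ring-bearing group for ethylcarbamoyl

The source may hold more compounds than are shown below. What is called first, only, known or untested is meant among the compounds shown, and "the series" means these compounds.

Values in a functional assay on HUVEC cells (Homo sapiens) for inhibition; a lower number here means a stronger inhibitor, a higher number a weaker inhibitor
Compound 1 `CN(c1ccc(N/C(S)=N/c2ccccc2)cc1)c1ccnc(Nc2cccc(CS(C)(=O)=O)c2)n1` gives 6 nM
Compound 2 `CN(c1ccc(NC(=O)Nc2ccc(OC(F)(F)F)cc2)cc1)c1ccnc(Nc2cccc(S(N)(=O)=O)c2)n1` gives 5 nM
Compound 3 `CN(c1ccc(NC(=O)Nc2ccc(OC(F)(F)F)cc2)cc1)c1ccnc(Nc2ccc(S(N)(=O)=O)cc2)n1` gives 37 nM

The value of compound 1 lies within the usual scatter of that of compound 2, and only compound 3 reads clearly higher. Compound 4 `CCNC(=O)Nc1ccc(N(C)c2ccnc(Nc3cccc(CS(C)(=O)=O)c3)n2)cc1` keeps the core of compound 1 but changes one group, with ethylcarbamoyl entering: a group of 5 heavy atoms (3 carbon, 1 nitrogen, 1 oxygen; no ring) in place of a group of 9 heavy atoms (7 carbon, 1 nitrogen, 1 sulfur; one six-membered aromatic ring of carbon only), on a nitrogen on an aromatic ring is the whole change. Within the data shown here, no measured step touches this group. Among the measured compounds shown here, the only step available is a 7.4-fold higher number from compound 2 to compound 3 (0.87 log units; beyond the scatter) and it lies elsewhere in the molecule, yet it shows that a single change can move this assay beyond the scatter. Compounds 1, 2 and 3 all carry an aromatic ring in this group and compound 4 has none, so the data do not show what losing it does. With compound 1 at 6 nM among the low numbers, a rise is expected more than a fall. The expected step is a 6.7-fold higher number from compound 1 to compound 4 (0.82 log units; beyond the scatter) and it is uncertain. Compound 4 is estimated at 40 nM with an expected range from 8 nM to 200 nM.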

Compound 4, half-maximal inhibitory concentration: 3 nM
The estimate for compound 4 lay 13-fold (1.12 log units) above the measured number; measured number below the stated range.
By their numbers in this assay, from the lowest: compounds 4, 2 and 1 (each within the scatter of the next); then compound 3.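

The step of a 2.0-fold lower number from compound 1 to compound 4 (0.30 log units; within the scatter) in this assay shows that, on this nitrogen on an aromatic ring, ethylcarbamoyl can stand in for the larger ring-bearing group without a difference the assay can separate from its usual scatter. The six-membered aromatic ring of the group that leaves is therefore not needed for a low number with the core of compound 1, something compounds 1, 2 and 3 could not show, since all of them carry an aromatic ring in this group. Nothing given here explains why the two groups read alike.

Going by these compounds, whether a longer chain, or a chain ending in an amine or a carboxylic acid, would also hold a low number stays open. So does whether ethylcarbamoyl would read the same way on the core of compound 2.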